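The source may hold more compounds than are shown below. What is called first, only, known or untested is meant among the compounds shown, and "the series" means these compounds.

Measured so far:
- compound 1 `C=CC(=O)Nc1cc(Nc2ncc3[nH]c(=O)n(-c4ccc(I)cc4)c3n2)c(OC)cc1N(C)CCN(C)C`: 4820 nM
- compound 2 `C=CC(=O)Nc1cc(Nc2ncc3[nH]c(=O)n(-c4ccc(C(C)C)cc4)c3n2)c(OC)cc1N1CCN(C)CC1`: 14300 nM

In an ADME assay on HT-29 cells (Homo sapiens) for cytotoxicity, read by MTT assay, with a stated time of 72 h (a lower number here means a stronger inhibitor, a higher number a weaker inhibitor), compound 1 gives 4820 nM, and compound 2 gives 14300 nM. Compound 2 therefore stands with the higher, that is weaker, of the two numbers, and the gap to compound 1 lies beyond the usual scatter. The two compounds differ in more than one place, so their values alone do not tell which change matters.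

Compound 3 `C=CC(=O)Nc1cc(Nc2ncc3[nH]c(=O)n(-c4ccc(I)cc4)c3n2)c(OC)cc1N1CCN(C)CC1` has not yet been measured. It differs from compound 2 in a single place: iodo in place of isopropyl on an aromatic carbon. Going by the values given here, no measured pair isolates this change. A modest drop in the number is expected, guided by compound 1, which carries the same iodo group and gives 4820 nM in this assay. For compound 3 the expected value in this assay is 6500 nM, within a range of 2500 nM to 18000 nM. That expectation amounts to a step of a 2.2-fold lower number from compound 2 to compound 3 (0.34 log units; beyond the scatter), about at the edge of the scatter.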

Compound 3, half-maximal inhibitory concentration: 39300 nM
Beside the measured number, compound 3's estimate is 6.0-fold (0.78 log units) below it, and the stated range ends below it.
By their numbers in this assay, from the lowest: compound 1; then compound 2; then compound 3.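

In this assay, iodo in place of isopropyl on the aromatic carbon gives a 2.7-fold higher number from compound 2 to compound 3 (0.44 log units; beyond the scatter), so with the 4-methylpiperazin-1-yl group held fixed, the iodo compound is the weaker inhibitor of this pair. With iodo held fixed, 4-methylpiperazin-1-yl in place of (2-(dimethylamino)ethyl)(methyl)amino gives an 8.2-fold higher number from compound 1 to compound 3 (0.91 log units; beyond the scatter), which shows that iodo alone does not account for the lower number of compound 1. No measurement shown here explains either step.

From the compounds shown here alone, it remains open whether the step from isopropyl to iodo runs the same way alongside the (2-(dimethylamino)ethyl)(methyl)amino group. Going by these compounds, it is also open how other groups on this aromatic carbon, such as chloro, methoxy or a carboxylic acid, would read in this assay.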